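The source may report more compounds than this note shows. Statements on the series, on what has been measured and on what is new or still open speak of the compounds shown alone.

In a functional assay for inhibition, with Homo sapiens as the target (a higher number here means a weaker inhibitor, a lower number a stronger inhibitor), compound 1 (`Clc1cccc(Nc2nccc(-c3cccnc3)n2)c1`) gives 1500 nM and compound 2 (`c1cncc(-c2ccnc(Nc3ccc(-n4ccnc4)cc3)n2)c1`) gives 1300 nM as its reading. For the measured compounds named here, the two numbers lie within the scatter of each other, so compound 1 stands level with the only other measured compound. Compound 3 (`CC(=O)Nc1cccc(Nc2nccc(-c3cccnc3)n2)c1`) keeps the core of compound 1 and carries acetamido in place of chloro on an aromatic carbon, meta to a large group (acetamido in place of chloro on an aromatic carbon). Going by the values given here, no measured pair differs in one place only, so this step has no direct precedent. Set against compound 1, compound 2 carries a different group and still reads 1300 nM in this series, so a small step is expected, most likely none beyond the scatter, with a slight lean to a lower number. The expected change is a 1.5-fold lower number from compound 1 to compound 3 (0.18 log units; within the scatter) as estimated here. In this assay the estimate for compound 3 is 1000 nM with an expected range from 300 nM to 3500 nM as its interval.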

Compound 3, half-maximal inhibitory concentration: 3600 nM
Estimate against measurement, compound 3: 3.6-fold (0.56 log units) below, outside the stated range (above it).
By their numbers in this assay, from the lowest: compounds 2 and 1 (each within the scatter of the next); then compound 3.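

In this assay, for the compounds shown here, the aromatic carbon meta to a large group gives the first single change that can be read: acetamido in place of chloro produces a 2.4-fold higher number from compound 1 to compound 3 (0.38 log units; beyond the scatter) on the weaker side. The change takes the substituent from 1 heavy atom to 4 heavy atoms and brings in 1 hydrogen-bond donor and 1 hydrogen-bond acceptor, so this position does not accept every replacement of chloro without a modest loss. No measurement here bears on what lies behind this step, and no single feature of acetamido can be singled out.

The compounds shown leave open whether the step follows the amide itself or the higher heavy-atom count. An amine or a methoxy group on the same aromatic carbon would help separate these two readings.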